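Side-chain variation at the urea-bearing carbon

The source may report more compounds than this note shows. Statements on the series, on what has been measured and on what is new or still open speak of the compounds shown alone.

Within the data shown here, compound 2 `N#C[C@H](CCc1ccccc1)NC(=O)[C@@H](NC(=O)N1CCOCC1)C1CCCCC1` gives 84 nM in an assay for inhibition of cathepsin S (Homo sapiens) (on this read-out higher numbers stand for weaker inhibition and lower numbers for stronger inhibition), the higher of the two numbers in hand; the nearest is compound 1 `CC(C)C[C@H](NC(=O)N1CCOCC1)C(=O)N[C@H](C#N)CCc1ccccc1` with 47 nM, and the only measured step, a 1.8-fold higher number from compound 1 to compound 2 (0.25 log units; within the scatter), lies within the scatter. Compound 3 `CC(C)(C)C[C@H](NC(=O)N1CCOCC1)C(=O)N[C@H](C#N)CCc1ccccc1` is not yet measured in this assay. It differs from compound 2 in one place: neopentyl in place of cyclohexyl on a saturated chain carbon bound to an amide-type nitrogen and a carbonyl carbon. Among the measured compounds shown here, the one step that bears on this is the earlier exchange of isobutyl for cyclohexyl at the same carbon, a 1.8-fold higher number from compound 1 to compound 2 (0.25 log units; within the scatter), which did not move the number beyond the scatter. Neopentyl is a branched chain without a ring, closer in kind to the isobutyl of compound 1 than to the ring of compound 2, so no step beyond the scatter is expected in either direction. For compound 3 the expected step from compound 2 is a 1.4-fold lower number from compound 2 to compound 3 (0.15 log units; within the scatter). Compound 3 is estimated at 60 nM, between 25 nM and 150 nM.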

Compound 3, half-maximal inhibitory concentration: 23 nM
Compound 3: middle estimate off by 2.6-fold (0.42 log units), on the high side, outside the stated range (below it).
By their numbers in this assay, from the lowest: compound 3; then compounds 1 and 2 (each within the scatter of the next).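

At the saturated chain carbon bound to an amide-type nitrogen and a carbonyl carbon, the side chain can move the number in this assay beyond the scatter: neopentyl in place of cyclohexyl gives a 3.7-fold lower number from compound 2 to compound 3 (0.56 log units; beyond the scatter) on this series. Even methyl in place of hydrogen on a saturated chain carbon bound to three saturated chain carbons, which turns isobutyl into neopentyl, gives a 2.0-fold lower number from compound 1 to compound 3 (0.31 log units; beyond the scatter) and so also passes the scatter, leaving compound 3 lowest of the three. Nothing in hand accounts for the advantage of neopentyl at this carbon.

From the compounds shown here alone, whether a longer chain, such as 3,3-dimethylbutyl, keeps the number this low remains open. So does the outcome with a smaller ring such as cyclopentyl, or with an amine or a carboxylic acid on the side chain.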